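A few compounds are considered here, and "the series" means these few. Any claim that something is new, unique, unknown or untested is made for them only; others in the source may bear on it.

Working notes on the series. The shared core is carried by compound 1 `CCC(C)C(NC(=O)n1nnc2ccccc21)C(=O)NC1CCCCC1`, compound 2 `CCC(C)C(NC(=O)n1nnc2ccccc21)C(=O)NCc1ccccc1` and compound 3 `CC(C)C(NC(=O)n1nnc2ccccc21)C(=O)NC1CCCC1`. In a functional assay on HEp-2 cells (Homo sapiens) for inhibition (a lower number here means a stronger inhibitor, a higher number a weaker inhibitor), compound 1 gives 57900 nM. Compound 2 reaches only the limit of this assay, > 100000 nM, and no number. Compound 3 gives 60300 nM in this assay; among the two numbers shown it is the highest, and its nearest neighbour is compound 1, a gap within the scatter. Within the data shown here, the one measured step, an at least 1.7-fold higher number from compound 1 to compound 2 (0.23 log units; that floor lies within the scatter), rests on a limit of > 100000 nM in this assay, at which 1 of the 3 values shown sits, and so is a floor only.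

Compound 4 `CCC(C)C(NC(=O)n1nnc2ccccc21)C(=O)NC1CCCC1` is not yet measured in this assay. From compound 3 it differs by methyl in place of hydrogen on a saturated chain carbon, three bonds along the chain from an amide-type nitrogen and a carbonyl carbon, so the chain on the carbon bearing the two amide-type groups reads isopropyl to sec-butyl. Among the measured compounds shown here, no measured step touches this position; the only measured step concerns the amide-type nitrogen and cannot be carried over. With compound 1 and compound 3 sitting within the scatter of each other while differing at the same chain, the step is expected to be small, a 1.1-fold lower number from compound 3 to compound 4 (0.04 log units; within the scatter), in no firm direction. Compound 4 is therefore estimated at 55000 nM in this assay, within 25000 nM to 120000 nM.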

Compound 4, half-maximal inhibitory concentration: 55700 nM
Compound 4: the middle estimate sits 1.0-fold (0.01 log units) below what was measured, within the range that was stated.
By their numbers in this assay, from the lowest: compounds 4, 1 and 3 (each within the scatter of the next). At a limit, above all of these: compound 2.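

Among these compounds, the first direct pair at this position, a 1.1-fold lower number from compound 3 to compound 4 (0.03 log units; within the scatter), shows that in this assay the isopropyl and sec-butyl chains cannot be told apart on the cyclopentyl amide, so methyl in place of hydrogen at this carbon gives no readable step. With sec-butyl held constant, a 1.0-fold lower number from compound 1 to compound 4 (0.02 log units; within the scatter), so cyclopentyl and cyclohexyl on the amide-type nitrogen also cannot be told apart, a comparison that compound 1 and compound 3 could not give, as they differ in two places. The other step on that nitrogen, an at least 1.7-fold lower number from compound 2 to compound 4 (0.25 log units; that floor lies within the scatter), rests on the value of compound 2, which is a limit and not a number, so it gives a floor only and no size for cyclopentyl in place of benzyl: the limit of > 100000 nM in this assay, at which 1 of the 4 values shown sits.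

On these data alone, whether a longer chain, such as n-hexyl, or a chain ending in a carboxylic acid or an amine would separate from isopropyl and sec-butyl at this carbon remains open. Also open, as far as these compounds go, is whether an amine-bearing ring on the amide-type nitrogen would give a number that stands clear of those of compound 1, compound 3 and compound 4.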